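Hydrazone aryl swap in the diaryl ether urea series

A few compounds are considered here, and "the series" means these few. Any claim that something is new, unique, unknown or untested is made for them only; others in the source may bear on it.

Compound 2 `CN(C)CCn1cnnc1-c1cc(Oc2ccc(NC(=O)N/N=C/c3c[nH]c4ccccc34)cc2F)ccn1` carries a 1H-indol-3-yl on the carbon with a double bond to nitrogen. In a functional assay on NCI-H460 cells (Homo sapiens) for cytotoxicity, read by MTT assay, with a stated time of 72 h (a higher number here means a weaker inhibitor, a lower number a stronger inhibitor), compound 2 gives 1630 nM. Among the compounds with values here, its only measured neighbour is compound 1 `CN(C)CCn1cnnc1-c1cc(Oc2ccc(NC(=O)N/N=C/c3ccc(O)cc3)cc2F)ccn1`, which bears 4-hydroxyphenyl in the same place; in this assay compound 1 gives 1780 nM. The two numbers sit within the usual scatter of each other, so compound 2 cannot be set apart from compound 1 on these figures: a 1.1-fold lower number from compound 1 to compound 2 (0.04 log units; within the scatter).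

Compound 3 `COc1cc(/C=N/NC(=O)Nc2ccc(Oc3ccnc(-c4nncn4CCN(C)C)c3)c(F)c2)cc(OC)c1OC` changes the same position once more: 3,4,5-trimethoxyphenyl in place of 1H-indol-3-yl on a carbon with a double bond to nitrogen. Within the data shown here, only one measured step bears on this position, the one from compound 1 to compound 2, and it was within the scatter. Among the measured compounds shown here, on that single precedent, the aryl group on the carbon with a double bond to nitrogen has not moved the numbers in this assay beyond the scatter, and no measured step speaks for 3,4,5-trimethoxyphenyl in particular. For compound 3 the step expected is therefore a 1.0-fold higher number from compound 2 to compound 3 (0.02 log units; within the scatter), none beyond the scatter. Compound 3 is estimated at 1700 nM, with a range from 800 nM to 3600 nM that allows for a change the one precedent has not shown.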

Compound 3, half-maximal inhibitory concentration: 2770 nM
Compound 3: middle estimate off by 1.6-fold (0.21 log units), on the low side; measured number inside the range.
By their numbers in this assay, from the lowest: compounds 2, 1 and 3 (each within the scatter of the next).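

With 3,4,5-trimethoxyphenyl, the aryl groups on the carbon with a double bond to nitrogen in this assay now include one with 0 hydrogen-bond donors and 3 hydrogen-bond acceptors, against 1 hydrogen-bond donor and 0 hydrogen-bond acceptors for 1H-indol-3-yl. Within the data shown here, neither step to it leaves the scatter: the change from 1H-indol-3-yl (a 1.7-fold higher number from compound 2 to compound 3 (0.23 log units; within the scatter)) and the change from 4-hydroxyphenyl (a 1.6-fold higher number from compound 1 to compound 3 (0.19 log units; within the scatter)) are both too small to set compound 3 apart, so the single earlier precedent now has two more steps of the same kind beside it, among three different aryl groups. No supporting measurement is available to explain these numbers.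

As far as these compounds go, whether this position would still give numbers within the scatter of one another with a carboxylic acid or an amine on the aryl group, or with a plain methyl in place of the aryl group, stays open. All three compounds share the same core, so the figures also leave open how much of the cytotoxicity depends on that core rather than on the group at this position.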